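The compounds below may be only part of what the source reports. "The series", "measured", "known", "first", "only" and "open" are said of these compounds alone.

Compound 1 `O=C1Nc2cc(Cl)c(F)cc2/C1=N/NC(=S)Nc1ccc(Cl)cc1` gives 48000 nM; compound 2 `Cc1ccc(NC(=S)N/N=C2\C(=O)Nc3cc(Cl)c(F)cc32)cc1` gives 132000 nM; compound 3 `Cc1ccc(CN2C(=O)/C(=N\NC(=S)Nc3ccc(Cl)cc3)c3cc(Cl)ccc32)cc1` gives 18000 nM, all in a functional assay on CCRF-CEM cells (Homo sapiens), with a stated time of 72 h; on this read-out lower numbers stand for stronger inhibition and higher numbers for weaker inhibition.

Compound 4 `O=C1/C(=N\NC(=S)Nc2ccc(Cl)cc2)c2cc(Cl)ccc2N1Cc1ccc(Cl)cc1` has not yet been measured in this assay. It differs from compound 3 by chloro in place of methyl on an aromatic carbon. The same kind of change links compound 2 to compound 1, (chloro in place of methyl on an aromatic carbon), which produced a 2.8-fold lower number from compound 2 to compound 1 (0.44 log units; beyond the scatter); there the wider reading is (4-methylphenyl)amino to (4-chlorophenyl)amino, whereas from compound 3 to compound 4 it reads 4-methylbenzyl to 4-chlorobenzyl. The difference between the cores of compound 2 and compound 3 is not broken down here. Because the earlier step was a 2.8-fold lower number from compound 2 to compound 1 (0.44 log units; beyond the scatter), a comparable move is expected for compound 4, tempered by the different surroundings: an estimated 1.8-fold lower number from compound 3 to compound 4 (0.26 log units; within the scatter). Compound 4 is therefore estimated at 10000 nM, between 4000 nM and 25000 nM.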

Compound 4, half-maximal inhibitory concentration: 68000 nM
Compound 4: the middle estimate sits 6.8-fold (0.83 log units) below what was measured; measured number above the stated range.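

Replacing 4-methylbenzyl with 4-chlorobenzyl gives a 3.8-fold higher number from compound 3 to compound 4 (0.58 log units; beyond the scatter) in this assay, so chloro in place of methyl does not carry a single direction across this series. Set beside the change from (4-methylphenyl)amino to (4-chlorophenyl)amino, the two steps run in opposite directions: the same change on two cores in this assay, a 2.8-fold lower number (0.44 log units; beyond the scatter) from compound 2 to compound 1 and a 3.8-fold higher number (0.58 log units; beyond the scatter) from compound 3 to compound 4, 10-fold (1.02 log units) apart, beyond the scatter of two such steps. This shows that the outcome of the change depends on its setting, but it does not show whether the site of the change or the difference between the cores decides it, as the two pairs differ in both.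

The compounds shown leave open how a fluoro or methoxy group would read in the same place on the benzyl group. They also leave open whether the change from (4-methylphenyl)amino to (4-chlorophenyl)amino, with the 4-methylbenzyl group kept, would follow the earlier step or the new one.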